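Sulfamoyl series: replacing hexylamino by methyl(octyl)amino

A few compounds are considered here, and "the series" means these few. Any claim that something is new, unique, unknown or untested is made for them only; others in the source may bear on it.

The series is followed in an assay on liver for inhibition of sterol O-acyltransferase 1 (Rattus norvegicus), using microsomes; a lower number here means a stronger inhibitor, a higher number a weaker inhibitor. Compound 1 `C=CCN(CC)S(=O)(=O)NC(=O)Nc1c(C(C)C)cccc1C(C)C` gives 2100 nM. Compound 2 `CC(C)c1cccc(C(C)C)c1NS(=O)(=O)NC(=O)NC(c1ccccc1)c1ccccc1` gives 30000 nM. Compound 3 `CCCCCCNS(=O)(=O)NC(=O)Oc1c(C(C)(C)C)cc(C)cc1C(C)(C)C` gives 19400 nM. Among these three numbers compound 3 holds the second highest; its nearest neighbour is compound 2, whose value lies within the usual scatter of it, so no order between compound 2 and compound 3 can be read. Its furthest neighbour is compound 1, whose number lies beyond the scatter below it.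

Compound 4 `CCCCCCCCN(C)S(=O)(=O)NC(=O)Oc1c(C(C)(C)C)cc(C)cc1C(C)(C)C` has not been measured. It differs from compound 3 in one place: methyl(octyl)amino in place of hexylamino on a sulfonyl sulfur. For the measured compounds named here, no measured pair shows this particular change, so its size is not known from data. Going by the values given here, the only compound carrying two alkyl groups on the sulfamoyl nitrogen is compound 1, and it gives the lowest number of the three; on that slender basis a moderate step towards a lower number, somewhat beyond the scatter, is expected from compound 3 to compound 4, a 2.4-fold lower number from compound 3 to compound 4 (0.38 log units; beyond the scatter). Among the compounds with values here, the estimate for compound 4 in this assay is therefore 8000 nM, with a range from 3000 nM to 25000 nM, the uncertainty being wide because compound 3 gives 19400 nM and no closer precedent exists.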

Compound 4, half-maximal inhibitory concentration: 18000 nM
Compound 4: the middle estimate sits 2.3-fold (0.35 log units) below what was measured; measured number inside the range.
By their numbers in this assay, from the lowest: compound 1; then compounds 4, 3 and 2 (each within the scatter of the next).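

In this assay the series now has its first pair differing in one place, and it gives a 1.1-fold lower number from compound 3 to compound 4 (0.03 log units; within the scatter), a step within the scatter. On a sulfonyl sulfur, then, methyl(octyl)amino in place of hexylamino produces no readable shift on this core, although the change removes the hydrogen-bond donor of hexylamino and goes from 7 to 10 heavy atoms. Compound 1 differs from compound 4 in more than one place, so it offers no reading of this change, and nothing available bears on why the number holds.

The change alters two things at once, the added methyl on the nitrogen and the longer chain, and neither methylhexylamino nor octylamino is among the compounds shown, so the two contributions cannot be separated and may or may not cancel. Also open, going by these compounds, is whether a ring amine such as piperidine, or a chain ending in a carboxylic acid, would move the number beyond the scatter at this position, and whether the same replacement would behave alike on the core of compound 1.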